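The compounds below may be only part of what the source reports. "The series", "measured", "known", "first", "only" and "open" are said of these compounds alone.

Among the compounds with values here, compound 3 `COc1cc(-c2nn(-c3cccc(NC(=O)Nc4ccc(Cl)c(C(F)(F)F)c4)c3)cc2-c2ccncc2)ccc1Cl` is the one compound of the three measured for which a functional assay on MOLT-4 cells (Homo sapiens) for inhibition, read by sulforhodamine B assay, with a stated time of 48 h (a lower number here means a stronger inhibitor of growth, a higher number a weaker inhibitor of growth), returns a number: in this assay compound 3 gives 7960 nM. Compound 1 `O=C(Nc1cccc(-n2cc(-c3ccncc3)c(-c3ccc(Cl)c(O)c3)n2)c1)Nc1cccc(C(F)(F)F)c1` gives only a limit of the assay, > 32500 nM. Compound 2 `O=C(Nc1cccc(-n2cc(-c3ccncc3)c(-c3ccc(Cl)c(O)c3)n2)c1)Nc1ccc(Cl)c(Cl)c1` likewise gives only a limit, > 32500 nM. Within the data shown here, the one step between measured compounds, a step that the two limits leave unreadable from compound 1 to compound 2, concerns the aryl group on the urea nitrogen and cannot be read because both of its ends are limits.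

Compound 4 `O=C(Nc1cccc(-n2cc(-c3ccncc3)c(-c3ccc(Cl)c(O)c3)n2)c1)Nc1ccc(Cl)c(C(F)(F)F)c1` is reached from compound 3 by a single change: hydrogen in place of methyl on an oxygen on an aromatic ring. Among the measured compounds shown here, no measured step covers this exact change, so the expectation rests on what the three values show. For the measured compounds named here, compounds 1 and 2, which carry the hydroxy group that enters here, both sit at the limit of > 32500 nM in this assay, at which 2 of the 3 values shown sit, whereas compound 3, which carries methoxy, is the only one to give a number. On that basis the step from compound 3 to compound 4 is expected to make the compound a weaker inhibitor of growth, a 3.1-fold higher number from compound 3 to compound 4 (0.50 log units; beyond the scatter), with a real chance that only a limit is returned. In this assay compound 4 is therefore estimated at 25000 nM, within a range from 8000 nM to 70000 nM.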

Compound 4, concentration for total growth inhibition: 2930 nM
Compound 4: the middle estimate sits 8.5-fold (0.93 log units) above what was measured; the measured number lies below the stated range.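

At the oxygen on the aromatic ring, the change from methoxy to hydroxy in this assay gives a 2.7-fold lower number from compound 3 to compound 4 (0.43 log units; beyond the scatter), so the hydroxy group is compatible here with a measurable and somewhat lower number, something compounds 1 and 2 could not show. With the hydroxy group kept, the rest of the molecule clearly matters: chloro in place of hydrogen on an aromatic carbon gives an at least 11-fold lower number from compound 1 to compound 4 (1.04 log units; beyond the scatter), and trifluoromethyl in place of chloro on an aromatic carbon gives an at least 11-fold lower number from compound 2 to compound 4 (1.04 log units; beyond the scatter). The true sizes of these last two steps may be larger, since the values for compounds 1 and 2 are limits of the assay and not numbers: the limit of > 32500 nM in this assay, at which 2 of the 4 values shown sit.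

Within the data shown here, the methoxy-to-hydroxy change is seen here in only one pair, so whether it would give a similar step with a different group on the other aromatic ring remains open. Also open, as far as these compounds go, is how this position would respond to an amine in place of the hydroxy group, or to a longer chain such as ethoxy in place of methoxy.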